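The source may report more compounds than this note shows. Statements on the series, on what has been measured and on what is new or still open speak of the compounds shown alone.

Compound 1 `O=C(NCc1cc(Cl)ccc1-n1cnnn1)[C@@H]1C[C@@H]2C[C@@H]2N1C(=O)[C@H](O)Cc1ccccn1` is one of three compounds with a reading in an ADME assay on liver for metabolic stability, with Liver microsome (Homo sapiens) as the target, read by LC-MS, using microsomes (on this read-out higher numbers stand for fast clearance and lower numbers for slow clearance), where compound 1 gives 17 mL.min-1.g-1. Compound 3 `CC(C)CC[C@@H](O)C(=O)N1N=CC[C@H]1C(=O)NCc1cc(Cl)ccc1-n1cnnn1` gives 47 mL.min-1.g-1 in this assay, a higher number than compound 1, whose number is the lower of the two that are reported as numbers. Compound 2 `COC(C)(C)[C@@H](O)C(=O)N1N=CC[C@H]1C(=O)NCc1cc(Cl)ccc1-n1cnnn1` is reported in this assay only as a limit, < 12 mL.min-1.g-1, one of the values sitting at the limit of < 12 mL.min-1.g-1 in this assay, at which 1 of the 3 values shown sits. Within the pair that shares a core, the move an at least 3.9-fold higher number from compound 2 to compound 3 (0.59 log units; beyond the scatter), where a plain alkyl chain replaced a group carrying an oxygen, raised the number.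

Compound 4 `O=C(NCc1cc(Cl)ccc1-n1cnnn1)[C@@H]1C[C@@H]2C[C@@H]2N1C(=O)[C@H](O)CC1CC1` differs from compound 1 by the change (cyclopropyl in place of pyridin-2-yl on a saturated chain carbon, two bonds along the chain from a carbonyl carbon and an oxygen on a saturated carbon). Among the measured compounds shown here, the only measured step that resembles this in kind is the step from compound 2 to compound 3, where a hydrocarbon group entering on the side chain went with a higher number; compound 4 likewise gains a hydrocarbon group and loses a heteroaromatic ring, though on a different carbon and a different core. Compound 4 is therefore expected to show a modest rise, a 1.8-fold higher number from compound 1 to compound 4 (0.25 log units; within the scatter), to an estimated 30 mL.min-1.g-1, within 14 mL.min-1.g-1 to 65 mL.min-1.g-1.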

Compound 4, intrinsic clearance in microsomes: < 12 mL.min-1.g-1
Compound 4 was reported as a limit; the forecaster's own chance of this, stated with the estimate: 5%; middle value at least 2.5-fold (0.39 log units) away from the limit.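

At this position, on a saturated chain carbon, two bonds along the chain from a carbonyl carbon and an oxygen on a saturated carbon, cyclopropyl in place of pyridin-2-yl gives an at least 1.4-fold lower number from compound 1 to compound 4 (0.15 log units; that floor lies within the scatter). The pyridin-2-yl ring is thus not required for a low reading on the core of compound 1, and a hydrocarbon group entering the side chain does not by itself bring a higher number, unlike an at least 3.9-fold higher number from compound 2 to compound 3 (0.59 log units; beyond the scatter), which lies on another core and another carbon. Compound 4 is reported only as a limit in this assay: the limit of < 12 mL.min-1.g-1 in this assay, at which 2 of the 4 values shown sit.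

On these data alone, how far compound 4 lies under that limit stays open, and with it whether the step goes beyond the scatter. Also open, as far as these compounds go, is how an amine or a longer chain would read at this position on the same core.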